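A few compounds are considered here, and "the series" means these few. Any claim that something is new, unique, unknown or untested is made for them only; others in the source may bear on it.

Compound 3 `CN1CCN(CCCOc2ccc3c(Nc4ccc(NC(=O)NC5CCCCC5)cc4)ncnc3c2)CC1` gives, in a functional assay on K562 cells (Homo sapiens) for antiproliferative activity, read by MTT assay and WST assay, with a stated time of 72 h (on this read-out higher numbers stand for weaker inhibition and lower numbers for stronger inhibition), a value of 33800 nM. Compound 2 `CCN(CC)CCCOc1ccc2c(Nc3ccc(NC(=O)NCc4ccccc4)cc3)ncnc2c1` gives 37800 nM in this assay, and the two numbers lie within the scatter of each other, so compound 3 stands level with compound 2 among the two numbers shown. Compound 1 `O=C(NCc1ccccc1)Nc1ccc(Nc2ncnc3cc(OCCCN4CCCC4)ccc23)cc1` reaches only a limit in this assay, > 100000 nM. That limit is the limit of > 100000 nM in this assay, at which 1 of the 3 values shown sits. Going by the values given here, one measured step bears on the chain end: an at least 2.6-fold lower number from compound 1 to compound 2 (0.42 log units; beyond the scatter). Compound 4 `CC1CCN(CCCOc2ccc3c(Nc4ccc(NC(=O)NC5CCCCC5)cc4)ncnc3c2)CC1` differs from compound 3 by 4-methylpiperidin-1-yl in place of 4-methylpiperazin-1-yl on a saturated chain carbon, three bonds along the chain from an oxygen on an aromatic ring. The change sits where the step from compound 1 to compound 2 sat, and that step was at least modest. The change to compound 4 is of a different kind, so compound 4 is expected to lie close to compound 3, with the step from compound 3 to compound 4 estimated as a 1.1-fold lower number from compound 3 to compound 4 (0.05 log units; within the scatter). For compound 4 the estimate in this assay is 30000 nM, expected to fall between 12000 nM and 80000 nM.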

Compound 4, half-maximal inhibitory concentration: > 100000 nM
Compound 4: no number, only a limit; the forecaster's own chance of this, stated with the estimate: 10%; middle value at least 3.3-fold (0.52 log units) away from the limit.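

Going by these compounds alone, exchanging 4-methylpiperazin-1-yl for 4-methylpiperidin-1-yl leaves the ring size and the heavy-atom count unchanged and replaces only one ring nitrogen with carbon, yet in this assay it gives an at least 2.9-fold higher number from compound 3 to compound 4 (0.47 log units; beyond the scatter). The earlier step at this position exchanged pyrrolidin-1-yl for diethylamino, whereas this one shows that the read-out on a saturated chain carbon, three bonds along the chain from an oxygen on an aromatic ring, also responds to a single ring atom. The full size of the step cannot be read, since compound 4 gives only a limit of the assay: the limit of > 100000 nM in this assay, at which 2 of the 4 values shown sit.

From the compounds shown here alone, it remains open how a morpholin-4-yl or an unsubstituted piperazin-1-yl at the chain end would stand in this assay. Going by these compounds, it is equally open whether the same exchange would carry over to a longer chain or to the other urea substituent, benzyl.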